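Urea-aryl replacement on the shared core, binding assay

The source may hold more compounds than are shown below. What is called first, only, known or untested is meant among the compounds shown, and "the series" means these compounds.

Measured so far:
compound 1, `O=C(Nc1ccc(Br)cc1)Nc1ccc(Nc2ncnc3c2OCCN3)cc1`: 2220 nM
compound 2, `O=C(Nc1ccc(Nc2ncnc3c2OCCN3)cc1)Nc1cccc2ccccc12`: limit only

In a binding assay on isolated protein for inhibition of proto-oncogene tyrosine-protein kinase receptor Ret (Homo sapiens), read by 33P incorporation, with stated times of 15 min and 40 min (on this read-out higher numbers stand for weaker inhibition and lower numbers for stronger inhibition), compound 1 gives 2220 nM. For compound 2 this assay reports only a limit, > 10000 nM. Hence compound 2 stands at the limit of > 10000 nM in this assay, at which 1 of the 2 values shown sits, and no number is known for it; the step of an at least 4.5-fold higher number from compound 1 to compound 2 (0.65 log units; beyond the scatter) is therefore itself only a lower bound on the loss.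

Compound 3, `CC(C)(C)c1csc(NC(=O)Nc2ccc(Nc3ncnc4c3OCCN4)cc2)n1`, differs from compound 2 in one place: 4-(tert-butyl)-1,3-thiazol-2-yl in place of naphthalen-1-yl on an amide-type nitrogen.

Among the measured compounds shown here, only one measured step bears on this position, an at least 4.5-fold higher number from compound 1 to compound 2 (0.65 log units; beyond the scatter), and it shows that the group on this amide-type nitrogen can move the number beyond the scatter. For the measured compounds named here, no measured compound carries a five-membered heteroaromatic ring here. The direction rests on compound 2 sitting at a limit of this assay. It rests also on the smaller group in compound 1, which gave 2220 nM. The expected step of an at least 3.3-fold lower number from compound 2 to compound 3 (0.52 log units; beyond the scatter) is a return toward the number of compound 1, with wide uncertainty. Compound 3 is expected to give about 3000 nM in this assay, with a range of 500 nM to 15000 nM.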

Compound 3, half-maximal inhibitory concentration: 3150 nM
Compound 3: middle estimate off by 1.1-fold (0.02 log units), on the low side; low and high end bracket the measured number.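

In this assay, the 4-(tert-butyl)-1,3-thiazol-2-yl and 4-bromophenyl groups on this amide-type nitrogen cannot be told apart, with a 1.4-fold higher number from compound 1 to compound 3 (0.15 log units; within the scatter), so this position accepts a five-membered aromatic ring with 2 hetero atoms as well as a six-membered aromatic ring of carbon only. Naphthalen-1-yl is the group that stands apart among the three, with an at least 3.1-fold lower number from compound 2 to compound 3 (0.50 log units; beyond the scatter), and the heavy-atom count alone does not explain this, as the group that leaves and the group that enters differ little in it. That step is a bound rather than a measured size because compound 2 carries no number: the limit of > 10000 nM in this assay, at which 1 of the 3 values shown sits.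

The compounds shown leave open whether the tert-butyl group or the thiazole ring matters more, as the two enter together; an unsubstituted 1,3-thiazol-2-yl group would separate them. They also leave open whether a phenyl ring with a trifluoromethyl group or a carboxylic acid in place of the bromine would move the number beyond the scatter relative to compound 1.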